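The compounds below may be only part of what the source reports. "The series", "measured", "known", "first", "only" and "open" are said of these compounds alone.

Compound 1 `Cn1c(=O)c(S(=O)(=O)c2ccc(F)cc2F)cc2cnc(Nc3ccc4[nH]c(C(=O)O)cc4c3)nc21`: 10000 nM
Compound 2 `Cn1c(=O)c(S(=O)(=O)c2ccc(C(=O)O)cc2)cc2cnc(Nc3ccc4[nH]ccc4c3)nc21`: 5000 nM
Compound 3 `Cn1c(=O)c(S(=O)(=O)c2ccccc2)cc2cnc(Nc3ccc4cc[nH]c4c3)nc21`: 10000 nM

The three measured compounds share a common core and were tested in a functional assay on K562 cells (Homo sapiens) for inhibition, read by trypan blue exclusion, with a stated time of 72 h; on this read-out higher numbers stand for weaker inhibition and lower numbers for stronger inhibition. Compound 1 gives 10000 nM, level with compound 3 at the digits shown, and the two together stand at the highest number of the three. Compound 2 gives 5000 nM; the gap from compound 1 lies within the usual scatter, so nothing separates them. All three therefore show only weak inhibition in this assay, with no spread beyond the scatter among them.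

Compound 4 `Cn1c(=O)c(S(=O)(=O)c2ccc(F)cc2F)cc2cnc(Nc3ccc4cccc(O)c4n3)nc21` has not yet been measured. It differs from compound 1 in one place: 8-hydroxyquinolin-2-yl in place of 2-carboxy-1H-indol-5-yl on a nitrogen on an aromatic ring. Going by the values given here, no measured pair shows what such a change does, so any expectation rests on the narrow spread among compounds 1, 2 and 3, all of which sit at weak inhibition. Compound 4 is expected to show no change at the digits printed from compound 1 to compound 4 (within the scatter), a step of no size beyond the scatter in either direction. Compound 4 is estimated at 10000 nM in this assay, within a range from 3000 nM to 30000 nM.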

Compound 4, half-maximal inhibitory concentration: 5000 nM
Compound 4: the middle estimate sits 2.0-fold (0.30 log units) above what was measured; the measured number falls inside the stated range.
By their numbers in this assay, from the lowest: compounds 2, 4, 1 and 3 (each within the scatter of the next).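

In this assay, going by these compounds alone, putting 8-hydroxyquinolin-2-yl in place of 2-carboxy-1H-indol-5-yl on a nitrogen on an aromatic ring gives a 2.0-fold lower number from compound 1 to compound 4 (0.30 log units; within the scatter), and this is the first comparison in the set in which only one place differs. It shows that at this position the carboxylic acid and the five-membered aromatic ring can both give way to a hydroxyl group and a six-membered aromatic ring with 1 hetero atom, with the two compounds remaining within the scatter of each other and still at weak inhibition. Nothing measured here bears on the reason for this result.

Going by these compounds, it remains open whether any group at this position can move inhibition beyond the scatter, for example a phenyl ring carrying a piperazine or a morpholine, or a chain ending in a dimethylamine. On these data alone, it is also open whether this same exchange would stay as small if the rest of compound 1 were different, since a single step on one core cannot settle that.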